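Chain lengthening on the shared core of compound 1

This account rests on a few compounds, and the source may have more. Where it says the series, first, only, none or still open, it means among the compounds named here.

Compound 1 `CCc1cn([C@H]2C[C@@H]3OP(=O)(O)OC[C@H]3O2)c(=O)[nH]c1=O` sits at the top of the values seen in a functional assay on L1210 cells (Mus musculus); on this read-out higher numbers stand for weaker inhibition and lower numbers for stronger inhibition: its value > 500 ug/mL is a limit of the assay, not a number. Compound 2 `CCCCCCCCc1cn([C@H]2C[C@@H]3OP(=O)(O)OC[C@H]3O2)c(=O)[nH]c1=O` gives 193 ug/mL in this assay. Compound 3 `CCCCCCc1cn([C@H]2C[C@H](O)[C@@H](CO)O2)c(=O)[nH]c1=O`, built on a different core, gives 195 ug/mL in this assay. Among the compounds with values here, the one measured step is an at least 2.5-fold lower number from compound 1 to compound 2 (0.41 log units; beyond the scatter); its true size is open at the lower end, set only by the limit of > 500 ug/mL in this assay, at which 1 of the 3 values shown sits.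

Compound 4 `CCCCc1cn([C@H]2C[C@@H]3OP(=O)(O)OC[C@H]3O2)c(=O)[nH]c1=O` differs from compound 1 by ethyl in place of hydrogen on a saturated chain carbon, two bonds along the chain from an aromatic carbon. Within the data shown here, this is a shorter version of the change from compound 1 to compound 2, so that step bears on it directly, although no measured pair shows a change of exactly this size. Lengthening to hexyl brought compound 2 into the measurable range; a shorter lengthening is expected to move the number in the same direction, but not as far. The estimated step is an at least 1.2-fold lower number from compound 1 to compound 4 (0.09 log units; that floor lies within the scatter). Compound 4 is therefore expected to give about 400 ug/mL, within a range from 150 ug/mL to 1000 ug/mL, with a fair chance that only a limit is reported again.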

Compound 4, concentration for 50% inhibition: 33.5 ug/mL
For compound 4 the middle estimate is 12-fold (1.08 log units) above the measured one, outside the stated range (below it).
By their numbers in this assay, from the lowest: compound 4; then compounds 2 and 3 (each within the scatter of the next). At a limit, above all of these: compound 1.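

Adding ethyl to the chain on the shared core gives an at least 14-fold lower number from compound 1 to compound 4 (1.17 log units; beyond the scatter). Removing butyl from the longer chain gives a 5.8-fold lower number from compound 2 to compound 4 (0.76 log units; beyond the scatter), so in this assay the number does not fall steadily with chain length: among these three compounds, butyl gives the lowest number, and compound 2, with the longer octyl chain, goes against any such trend. The first step remains open in size, as compound 1 is held only by a limit: the limit of > 500 ug/mL in this assay, at which 1 of the 4 values shown sits.

The compounds shown do not tell whether the lowest number lies at butyl or at a neighbouring length such as hexyl on this core, nor whether a chain ending in an amine or a carboxylic acid would keep the number of compound 4. Compound 3 stands on a different core, so it does not settle either question.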